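The source may hold more compounds than are shown below. What is called first, only, known or untested is meant among the compounds shown, and "the series" means these compounds.

Working notes on a small series sharing one core with an acid-bearing chain.

Compound 1 `Cc1ccc(N(CCN2CCC(OCC(=O)O)CC2)C(=O)c2ccc(Cl)cc2)cc1` gives 690 nM in a functional assay on a cell-free system (Platelet, plasma, Homo sapiens) for inhibition; on this read-out lower numbers stand for stronger inhibition and higher numbers for weaker inhibition. Compound 2 `COc1ccc(C(=O)N(CCN2CCC(OCC(=O)O)CC2)c2ccc(C)cc2)cc1` differs from compound 1 by methoxy in place of chloro on an aromatic carbon, and in this assay compound 2 gives 1200 nM, a step of a 1.7-fold higher number from compound 1 to compound 2 (0.24 log units; within the scatter). Compound 3 `O=C(O)COC1CCN(CCN(C(=O)c2ccc(Cl)cc2)c2ccc(Cl)cc2)CC1` differs from compound 1 in the core by chloro in place of methyl on an aromatic carbon; in this assay compound 3 gives 1500 nM, a step of a 2.2-fold higher number from compound 1 to compound 3 (0.34 log units; beyond the scatter). The values of compound 2 and compound 3 lie within the scatter of each other.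

Compound 4 `COc1ccc(C(=O)N(CCN2CCC(OCC(=O)O)CC2)c2ccc(Cl)cc2)cc1` is not yet measured. It differs from compound 3 by methoxy in place of chloro on an aromatic carbon, the same change, at the same place, as that from compound 1 to compound 2; it appears in two pairs here. Among the measured compounds shown here, the step from compound 3 to compound 4 in this assay is expected to be a 1.6-fold higher number from compound 3 to compound 4 (0.20 log units; within the scatter), matching the earlier instance, because a 1.7-fold higher number from compound 1 to compound 2 (0.24 log units; within the scatter) stayed within the scatter and no other precedent exists. Compound 4 is estimated at 2400 nM, with a likely range from 1200 nM to 5000 nM.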

Compound 4, half-maximal inhibitory concentration: 3100 nM
For compound 4 the middle estimate is 1.3-fold (0.11 log units) below the measured one, within the range that was stated.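

In this assay, methoxy in place of chloro gives a 2.1-fold higher number from compound 3 to compound 4 (0.32 log units; beyond the scatter), and this step agrees with its earlier instance: the same change on two cores in this assay, a 1.7-fold higher number (0.24 log units; within the scatter) from compound 1 to compound 2 and a 2.1-fold higher number (0.32 log units; beyond the scatter) from compound 3 to compound 4, 1.2-fold (0.07 log units) apart, within the scatter of two such steps. Chloro in place of methyl gives a 2.6-fold higher number from compound 2 to compound 4 (0.41 log units; beyond the scatter), which likewise agrees with its earlier instance: the same change on two cores in this assay, a 2.2-fold higher number (0.34 log units; beyond the scatter) from compound 1 to compound 3 and a 2.6-fold higher number (0.41 log units; beyond the scatter) from compound 2 to compound 4, 1.2-fold (0.07 log units) apart, within the scatter of two such steps. Across these four compounds, each change therefore carries from one core to the other with little difference in size, but each comparison rests on only two instances in a single read-out and shows neither why the numbers rise nor whether the agreement holds on any other core.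

The compounds shown leave open how other groups at the same aromatic carbon, such as fluoro, a nitrile or an amine, would compare with chloro and methoxy. They also leave open whether the same steps would hold with a longer chain carrying the carboxylic acid, or with an amide in its place.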